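The source may hold more compounds than are shown below. What is called first, only, known or untested is meant among the compounds shown, and "the series" means these compounds.

Compound 1 `COc1cc(-c2nnc3n2NC(c2ccco2)C(C(=O)c2ccc(Cl)cc2)S3)cc(OC)c1OC` and compound 2 `COc1cc(-c2nnc3n2NC(c2ccco2)C(C(=O)C2CC2)S3)cc(OC)c1OC` share a core and differ only at a carbonyl carbon, with a step that the two limits leave unreadable from compound 1 to compound 2. In a functional assay on MCF7 cells (Homo sapiens) for cytotoxicity, read by MTT assay, with a stated time of 48 h (on this read-out higher numbers stand for weaker inhibition and lower numbers for stronger inhibition), compound 1 reaches only the limit > 100000 nM, which is a limit of the assay and not a number. In this assay compound 2 likewise reaches only the limit > 100000 nM. Both values sit at the limit of > 100000 nM in this assay, at which 2 of the 2 values shown sit. Compound 3 `COc1cc(-c2nnc3n2NC(c2ccco2)C(C(=O)c2ccccc2)S3)cc(OC)c1OC` differs from compound 2 by phenyl in place of cyclopropyl on a carbonyl carbon. With both neighbouring values at a limit, no step can be read, and the expected step of a number no higher from compound 2 to compound 3 (the limit leaves the size open) is none beyond the scatter. Compound 3 is therefore estimated at 100000 nM, within 30000 nM to 300000 nM.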

Compound 3, half-maximal inhibitory concentration: 39800 nM
For compound 3 the middle estimate is 2.5-fold (0.40 log units) above the measured one, and the stated range covers the measured number.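

Among the compounds shown here, compound 3 is the first compound here with a readable number in this assay, so a compound with this core can register in the assay: phenyl in place of cyclopropyl on a carbonyl carbon gives an at least 2.5-fold lower number from compound 2 to compound 3 (0.40 log units; beyond the scatter). A single chloro also matters, since hydrogen in its place on an aromatic carbon gives an at least 2.5-fold lower number from compound 1 to compound 3 (0.40 log units; beyond the scatter). Both sizes are only minimums because the starting values are limits and not numbers: the limit of > 100000 nM in this assay, at which 2 of the 3 values shown sit.

The step between compound 1 and compound 2 cannot be read. Going by these compounds, whether an amine on the phenyl ring, or a longer chain on the carbonyl carbon, would give a lower number stays open.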